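This account rests on a few compounds, and the source may have more. Where it says the series, first, only, none or still open, it means among the compounds named here.

Compound 1 `COc1ccc(COCC(Cn2ccnc2)OCc2ccc(OC)cc2)cc1` is the reference point of this small set. In a functional assay for inhibition of Thromboxane-A synthase (Homo sapiens) (a lower number here means a stronger inhibitor, a higher number a weaker inhibitor), compound 1 gives 9900 nM, the second highest of the three numbers measured. Compound 2 `CCCCOC(=O)c1ccc(COC(COCc2ccc(OC)cc2)Cn2ccnc2)cc1` gives 200 nM, and compound 3 `CCCCCCCCOC(=O)c1ccc(COC(COCc2ccc(OC)cc2)Cn2ccnc2)cc1` gives 21000 nM. The step of a 50-fold lower number from compound 1 to compound 2 (1.69 log units; beyond the scatter) is large, whereas the step of a 2.1-fold higher number from compound 1 to compound 3 (0.33 log units; beyond the scatter) is only modest, and between the two esters the step of a 110-fold higher number from compound 2 to compound 3 (2.02 log units; beyond the scatter) is large again. All three measured steps therefore concern the substituent on the aromatic carbon of one of the two aryl groups, and they show that altering it can move the number strongly in either direction.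

Compound 4 `COc1ccc(COCC(Cn2ccnc2)OCc2ccc3c(c2)COC3=O)cc1` differs from compound 1 in a different way: a group of 10 heavy atoms (8 carbon, 2 oxygen; one five-membered non-aromatic ring with 1 hetero atom, one six-membered aromatic ring of carbon only) in place of a group of 8 heavy atoms (7 carbon, 1 oxygen; one six-membered aromatic ring of carbon only), on a saturated chain carbon bound to an oxygen on a saturated carbon. Going by the values given here, no measured step reproduces this change, so the measured steps bear on it only indirectly. The step from compound 1 to compound 2 shows that a group carrying a carbonyl in place of the methoxy can lower the number greatly, while the step from compound 1 to compound 3 shows a modest rise, so a moderate decrease with wide uncertainty is expected, a 4.0-fold lower number from compound 1 to compound 4 (0.60 log units; beyond the scatter). For compound 4 the estimated value in this assay is 2500 nM, expected to fall between 300 nM and 15000 nM.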

Compound 4, half-maximal inhibitory concentration: 6200 nM
Estimate against measurement, compound 4: 2.5-fold (0.39 log units) below, within the range that was stated.
By their numbers in this assay, from the lowest: compound 2; then compounds 4 and 1 (each within the scatter of the next); then compound 3.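

In this assay, replacing the 4-methoxyphenyl group with the group holding a five-membered non-aromatic ring with 1 hetero atom, on a saturated chain carbon bound to an oxygen on a saturated carbon, gives a step that stays inside the usual scatter: a 1.6-fold lower number from compound 1 to compound 4 (0.20 log units; within the scatter). The earlier compounds shown here showed that a carbonyl-bearing group can accompany a large step, a 50-fold lower number from compound 1 to compound 2 (1.69 log units; beyond the scatter), and this result shows that a carbonyl-bearing group in the same place does not always do so, since here the carbonyl sits in a closed ring and not in an open butyl ester. Nothing among the data shown offers an explanation for this difference between the two carbonyl-bearing groups.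

The compounds shown leave open how an open methyl ester, a carboxylic acid or an amide would compare in this place, which would help to separate the effect of closing the ring from that of the carbonyl itself. They also leave open how a hexyl ester would fall, given the large step between the butyl and octyl esters, a 110-fold higher number from compound 2 to compound 3 (2.02 log units; beyond the scatter).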